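This account rests on a few compounds, and the source may have more. Where it says the series, first, only, none or still open, it means among the compounds named here.

Measured compounds:
compound 1 `CCc1cc2c(C(=O)c3ccc(OC)cc3)c(OC)ccc2o1` — 6.1%
compound 2 `CCc1cc2c(C(=O)c3ccc(OC)cc3)ccc(OC)c2o1` — 7.4%

In an assay for inhibition of solute carrier family 22 member 12 (Homo sapiens), read by scintillation counting, with a stated time of 60 min, tested at 50 uM (on this read-out higher numbers stand for more inhibition at the one concentration tested (going by the name of the read-out) and lower numbers for less inhibition), compound 1 gives 6.1% and compound 2 gives 7.4%; the two numbers lie within the scatter of each other, so neither stands apart, and both show little inhibition at the concentration tested. Compound 3 `CCc1cc2c(C(=O)c3ccc(O)cc3)c(OC)ccc2o1` differs from compound 1 by hydrogen in place of methyl on an oxygen on an aromatic ring. For the measured compounds named here, no measured pair shows a step of this kind, so the size of its effect in this assay is unknown; a step no larger than the scatter is expected, in either direction. For compound 3 the estimate in this assay is 10%, between 0% and 30%, which means an expected step of a number 3.9 percentage points higher from compound 1 to compound 3 (within the scatter).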

Compound 3, a percentage reported as inhibition, at one concentration (the size of the read-out at that concentration, not a potency): 88.2%
Estimate against measurement, compound 3: 78.2 percentage points below; the whole stated range lies below it.
By their numbers in this assay, from the lowest: compounds 1 and 2 (each within the scatter of the next); then compound 3.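

Hydrogen in place of methyl on an oxygen on an aromatic ring is the first change in the series to move the read-out: in this assay it gives a number 82.1 percentage points higher from compound 1 to compound 3 (beyond the scatter). Compounds 1 and 2 had shown only little inhibition, so this position is highly sensitive to the methoxy to hydroxy change. Nothing available explains the size of this step. On these data alone, whether an amine or a carboxylic acid on the ring at this place would keep the inhibition remains open. Also open, as far as these compounds go, is whether the same change would carry over to the core of compound 2.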